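The source may report more compounds than this note shows. Statements on the series, on what has been measured and on what is new or still open speak of the compounds shown alone.

Working notes on the series.

Compound 1 `COc1ccc(CCOc2ccc(-c3c(C)nc(C)c([C@H](OC(C)(C)C)C(=O)O)c3N3CCC(C)(C)CC3)cc2)cc1` carries a 2-(4-methoxyphenyl)ethyl group on the oxygen on the aromatic ring of the shared core. In an ADME assay on microsomes from liver (Rattus norvegicus) for metabolic stability, read by LC-MS, tested at 0.5 uM (on this read-out higher numbers stand for a longer-lived compound and lower numbers for a shorter-lived compound), compound 1 gives > 2 h, which is a limit of the assay and not a number. Compound 2 `Cc1nc(C)c([C@H](OC(C)(C)C)C(=O)O)c(N2CCC(C)(C)CC2)c1-c1ccc(OCCc2cc(F)c(F)cc2F)cc1` is its 2,4,5-trifluorophenyl counterpart; in this assay compound 2 gives > 2 h, again a limit. Compound 3 `Cc1nc(C)c([C@H](OC(C)(C)C)C(=O)O)c(N2CCC(C)(C)CC2)c1-c1ccc(OC2COCC2c2ccc(F)cc2)cc1` carries the 4-(4-fluorophenyl)oxolan-3-yl group; in this assay compound 3 gives > 2 h, also a limit. The steps between them are therefore not readable: a step that the two limits leave unreadable from compound 1 to compound 2, a step that the two limits leave unreadable from compound 1 to compound 3 and a step that the two limits leave unreadable from compound 2 to compound 3. What the three measurements do show is the limit of > 2 h in this assay, at which 3 of the 3 values shown sit.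

Compound 4 `Cc1ccc(CCOc2ccc(-c3c(C)nc(C)c([C@H](OC(C)(C)C)C(=O)O)c3N3CCC(C)(C)CC3)cc2)s1` differs from compound 1 as follows: 5-methylthiophen-2-yl in place of 4-methoxyphenyl on a saturated chain carbon, two bonds along the chain from an oxygen on an aromatic ring. For the measured compounds named here, no measured step reads out a size that bears on this change; all three measured steps are hidden by the limit. Going by the values given here, the only guide is that every measured variation of this side chain reaches the limit, so compound 4 is expected to do the same. The expected step is a step that the limit leaves unreadable from compound 1 to compound 4. Compound 4 is estimated at 3 h, in the range 1 h to 8 h.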

Compound 4, half-life: > 2 h
Compound 4: a limit, no number; the forecaster's own chance of this, stated with the estimate: 70%; the middle value does not contradict the limit.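

No step among compound 1, compound 2, compound 3 and compound 4 can be read, because each of the four values is a limit and not a number: the limit of > 2 h in this assay, at which 4 of the 4 values shown sit.

From the compounds shown here alone, whether these four compounds differ in half-life beyond that limit, and by how much, remains open.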